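Benzyl for Methyl on Selenium: Expectation for Compound 4

A few compounds are considered here, and "the series" means these few. Any claim that something is new, unique, unknown or untested is made for them only; others in the source may bear on it.

Measured so far:
compound 1, `C[Se]/C(=N\C(=O)c1cc2ccccc2s1)NC(=O)c1cc2ccccc2s1`, 490 nM
compound 2, `C[Se]/C(=N\C(=O)c1cccs1)NC(=O)c1cccs1`, 9260 nM
compound 3, `CS/C(=N\C(=O)c1ccco1)NC(=O)c1ccco1`, 8220 nM

Of the compounds shown here, three have been measured in an ADME assay on MCF-10A cells (Homo sapiens) for cytotoxicity, read by MTT assay, with a stated time of 72 h; a higher number here means a weaker inhibitor of growth, a lower number a stronger inhibitor of growth. Compound 1 stands lowest of the three numbers: compound 3 lies higher and compound 2 higher still, both gaps beyond the usual scatter, so compound 1 is the strongest inhibitor of growth among them. Compounds 2 and 3 lie within the scatter of each other, and nothing separates them.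

Compound 4, `O=C(/N=C(/NC(=O)c1cc2ccccc2s1)[Se]Cc1ccccc1)c1cc2ccccc2s1`, has not yet been measured. It differs from compound 1 in one place: phenyl in place of hydrogen on a saturated chain carbon bound to a selenium atom. Cut one bond further out, the same change reads methyl to benzyl on the selenium atom. For the measured compounds named here, no pair of measured compounds shows a step of this kind, so its size is not known from the data. The shared core of compound 1 is kept unchanged, and the number for compound 4 is expected to stay near that of compound 1, with a step of a 1.2-fold higher number from compound 1 to compound 4 (0.09 log units; within the scatter) that is estimated to fall at or near the scatter. Compound 4 is therefore estimated at 600 nM, in a range from 150 nM to 2500 nM.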

Compound 4, concentration for 50% growth inhibition: 37900 nM
Compound 4: the middle estimate sits 63-fold (1.80 log units) below what was measured; measured number above the stated range.
By their numbers in this assay, from the lowest: compound 1; then compounds 3 and 2 (each within the scatter of the next); then compound 4.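

In this assay the group on the selenium atom proves to be far from a silent place: with the shared core kept, the change from methyl to benzyl gives a 77-fold higher number from compound 1 to compound 4 (1.89 log units; beyond the scatter) and so moves the compound towards a much weaker inhibitor of growth. For the compounds shown here, compounds 1, 2 and 3 offered no step at this position, so this single pair is the first to show that a change here alone can shift the number by a large amount. No evidence at hand bears on why the number moves this far.

Going by these compounds, whether the step follows from the phenyl ring itself or from any group larger than methyl stays open, and an ethyl group or a longer chain on the selenium atom would speak to that. On these data alone, it also remains open whether the same change would do as much on the core of compound 2.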